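The source may report more compounds than this note shows. Statements on the series, on what has been measured and on what is new or still open speak of the compounds shown alone.

In an assay on HEK293 cells for inhibition of N-acylethanolamine-hydrolyzing acid amidase (Rattus norvegicus), read by LC-MS, with a stated time of 30 min (on this read-out lower numbers stand for stronger inhibition and higher numbers for weaker inhibition), compound 1 `O=C(CCCCCCc1ccccc1F)N1CCCC1` gives 13700 nM and compound 2 `O=C(CCCCCCc1ccc(F)cc1)N1CCCC1` gives 8000 nM. Compound 3 `O=C(CCCCCCc1ccccc1Cl)N1CCCC1` reaches only the assay limit of > 100000 nM in this assay. The step chloro in place of fluoro on an aromatic carbon produced an at least 7.2-fold higher number from compound 1 to compound 3 (0.86 log units; beyond the scatter), a step that is known only as a limit because of the limit of > 100000 nM in this assay, at which 1 of the 3 values shown sits. The difference between the cores of compound 1 and compound 2 is not broken down here. Compound 4 `O=C(CCCCCCc1ccc(Cl)cc1)N1CCCC1` has not been measured; it differs from compound 2 by chloro in place of fluoro on an aromatic carbon, the same kind of change as that from compound 1 to compound 3, though the place is para to a large group rather than ortho to a large group. Resting on the weakening seen in an at least 7.2-fold higher number from compound 1 to compound 3 (0.86 log units; beyond the scatter), a loss is expected, so a step of a 5.0-fold higher number from compound 2 to compound 4 (0.70 log units; beyond the scatter) is estimated in this assay, giving compound 4 an expected value near 40000 nM, between 10000 nM and 150000 nM.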

Compound 4, half-maximal inhibitory concentration: 34500 nM
Compound 4: middle estimate off by 1.2-fold (0.06 log units), on the high side; the range from low to high includes it.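

In this assay, chloro in place of fluoro again goes with weaker inhibition, giving a 4.3-fold higher number from compound 2 to compound 4 (0.63 log units; beyond the scatter), so the direction seen on the first core also appears on the second. Two pairs show only this shared direction and give no rule for cores beyond these. Whether the size of the step also carries over cannot be said, as one of the two steps rests on a limit rather than a number: the same change on two cores in this assay, an at least 7.2-fold higher number (0.86 log units; beyond the scatter) from compound 1 to compound 3 and a 4.3-fold higher number (0.63 log units; beyond the scatter) from compound 2 to compound 4; the limit leaves it open whether they differ

The compounds shown leave open whether a bromo or methoxy group in place of the fluoro would follow the same direction. They also leave open whether the step holds with a shorter or longer chain.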